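From Thiophen-2-yl to 1-Benzofuran-2-yl: Expecting Compound 4

The compounds below may be only part of what the source reports. "The series", "measured", "known", "first", "only" and "open" are said of these compounds alone.

Four compounds share one core and differ in the groups attached to it. Compound 1 `Cc1ncnc2c1c(-c1cccs1)cn2[C@@H]1O[C@H](CO)[C@@H](O)[C@H]1O` carries a methyl group and a thiophen-2-yl group; compound 2 `COc1ncnc2c1c(-c1cccs1)cn2[C@@H]1O[C@H](CO)[C@@H](O)[C@H]1O` has a methoxy group in place of that methyl. Compound 3 `Cc1nc(N)c2c(-c3cc4ccccc4o3)cn([C@@H]3O[C@H](CO)[C@@H](O)[C@H]3O)c2n1` bears a methyl, an amino group and a 1-benzofuran-2-yl group. Compound 4 `COc1ncnc2c1c(-c1cc3ccccc3o1)cn2[C@@H]1O[C@H](CO)[C@@H](O)[C@H]1O` has not yet been measured.

Among the compounds with values here, in a functional assay on HeLa S3 cells (Homo sapiens) for antiproliferative activity, read by XTT assay, with a stated time of 72 h (a higher number here means a weaker inhibitor, a lower number a stronger inhibitor), compound 2 gives 1760 nM, the only plain number among the three measured compounds. For compound 1 the assay reports only the limit > 15000 nM. For compound 3 it likewise reports only the limit > 20000 nM. Within the data shown here, the one step that can be sized, an at least 8.5-fold lower number from compound 1 to compound 2 (0.93 log units; beyond the scatter), marks the methoxy compound as the stronger of that pair.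

Compound 4 differs from compound 2 by 1-benzofuran-2-yl in place of thiophen-2-yl on an aromatic carbon. Among the measured compounds shown here, no measured step exchanges these two groups alone; compound 3 shows only that a compound carrying the 1-benzofuran-2-yl group, together with other differences, sits at a limit. Compound 4 is therefore expected to be at best similar to compound 2 and possibly weaker, an estimated 3500 nM with a range from 600 nM to 20000 nM. The step of a 2.0-fold higher number from compound 2 to compound 4 (0.30 log units; within the scatter) is expected to be a modest loss.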

Compound 4, half-maximal inhibitory concentration: 9240 nM
Estimate against measurement, compound 4: 2.6-fold (0.42 log units) below; low and high end bracket the measured number.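

In this assay, exchanging thiophen-2-yl for 1-benzofuran-2-yl while the methoxy group stays in place gives a 5.3-fold higher number from compound 2 to compound 4 (0.72 log units; beyond the scatter) and thus the first direct measure of a change at this aromatic carbon, showing that this position responds to the group it carries, and that compound 4 still gives a plain number with the added six-membered aromatic ring in place. Compound 3 also carries 1-benzofuran-2-yl, but differs in other places as well, and its > 20000 nM is a limit of the assay, so it could not show this. No measurement shown here accounts for the size of the step.

The exchange alters two things at once, adding a six-membered aromatic ring and putting oxygen where sulfur stood, and the compounds shown leave open which of these matters; a furan-2-yl group or a 1-benzothiophen-2-yl group at this carbon would separate the two. Also open, on these data alone, is whether the same exchange would give a similar step on a core carrying a methyl or an amino group rather than the methoxy group.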